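Pyrrolidin-3-yl in place of piperidin-4-yl on a carbonyl carbon

A few compounds are considered here, and "the series" means these few. Any claim that something is new, unique, unknown or untested is made for them only; others in the source may bear on it.

Measured compounds, in a physicochemical assay for solubility, at pH 7.4; on this read-out lower numbers stand for lower solubility and higher numbers for higher solubility:
- compound 1 `CC(C)(O)CCN1CCC(NS(=O)(=O)c2cc(S(=O)(=O)c3ccccc3)ccc2C(F)(F)F)CC1`: > 100000 nM (a limit)
- compound 2 `O=C(C1CCNCC1)N1CCC(NS(=O)(=O)c2cc(S(=O)(=O)c3ccccc3)ccc2C(F)(F)F)CC1`: > 100000 nM (a limit)

In this assay compound 2 gives > 100000 nM, which is a limit and not a number. Both measured compounds share (the limit of > 100000 nM in this assay, at which 2 of the 2 values shown sit), and no order between them can be read. Compound 3 `O=C([C@@H]1CCNC1)N1CCC(NS(=O)(=O)c2cc(S(=O)(=O)c3ccccc3)ccc2C(F)(F)F)CC1` differs from compound 2 as follows: pyrrolidin-3-yl in place of piperidin-4-yl on a carbonyl carbon, on a carbonyl carbon whose other neighbours are an amide-type nitrogen in a ring. For the measured compounds named here, the one measured step bearing on this is a step that the two limits leave unreadable from compound 1 to compound 2, and it offers no size to carry over. No step beyond the scatter is therefore expected, in either direction, and a report at the same limit is the likeliest outcome. In this assay the estimated change is a number no higher from compound 2 to compound 3 (the limit leaves the size open), as an expectation only. Compound 3 is estimated at 100000 nM, with an expected range from 50000 nM to 200000 nM, and this awaits measurement.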

Compound 3, solubility: 70000 nM
For compound 3 the middle estimate is 1.4-fold (0.15 log units) above the measured one; low and high end bracket the measured number.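

In this assay, for the compounds shown here, compound 3 is the first compound of the series to give a number and not a limit, so this position on the carbonyl carbon now has a readable value, whereas the step from compound 1 to compound 2 cannot be read. Pyrrolidin-3-yl in place of piperidin-4-yl gives an at least 1.4-fold lower number from compound 2 to compound 3 (0.15 log units; that floor lies within the scatter), and (pyrrolidin-3-yl)carbonyl in place of 3-hydroxy-3-methylbutyl gives an at least 1.4-fold lower number from compound 1 to compound 3 (0.15 log units; that floor lies within the scatter). Both steps are floors, not sizes, and neither shows a change beyond the scatter, with the limit still holding for the other two compounds: the limit of > 100000 nM in this assay, at which 2 of the 3 values shown sit.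

As far as these compounds go, the true size of either step stays open while compound 1 and compound 2 are known only as limits. Also open, from the compounds shown here alone, is how the opposite enantiomer of the pyrrolidin-3-yl group, or an azetidin-3-yl group on the same carbonyl carbon, would read in this assay.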